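Cytotoxicity notes: 3-methylphenyl for 4-fluorophenyl on the chain

The source may hold more compounds than are shown below. What is called first, only, known or untested is meant among the compounds shown, and "the series" means these compounds.

Compound 1 `CC(=O)N1CCc2nc(C)c(C(OC(C)(C)C)C(=O)O)c(-c3ccc(C)cc3)c2C1`: in an ADME assay on MT2 cells (Homo sapiens) for cytotoxicity, read by XTT assay, with a stated time of 4 days (on this read-out higher numbers stand for lower toxicity in this test and lower numbers for higher toxicity in this test), compound 1 gives > 40000 nM, a limit of the assay.
Compound 2 `Cc1nc2c(c(-c3cc(F)c4c(c3C)CCCO4)c1[C@H](OC(C)(C)C)C(=O)O)CN(CCCc1ccc(F)cc1)CC2`: compound 2 gives > 40000 nM, a limit.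
Compound 3 `Cc1ccc(-c2c3c(nc(C)c2C(OC(C)(C)C)C(=O)O)CCN(CCCC2CCCC2)C3)cc1`: compound 3 gives > 40000 nM, a limit.

For the measured compounds named here, the one single-place step measured, a step that the two limits leave unreadable from compound 1 to compound 3, is unreadable because both ends sit at the limit of > 40000 nM in this assay, at which 3 of the 3 values shown sit. Compound 2 therefore stands only at the limit, with no number, exactly where the other two values sit. Compound 4 `Cc1cccc(CCCN2CCc3nc(C)c([C@H](OC(C)(C)C)C(=O)O)c(-c4cc(F)c5c(c4C)CCCO5)c3C2)c1` differs from compound 2 by 3-methylphenyl in place of 4-fluorophenyl on a saturated chain carbon, three bonds along the chain from an amine nitrogen in a ring. Going by the values given here, no measured step bears on this change, so no direction can be read from the series. Compound 4 is expected to show a number no higher from compound 2 to compound 4 (the limit leaves the size open), nothing beyond the scatter, most likely again a limit. The estimate for compound 4 is 40000 nM, range 20000 nM to 100000 nM.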

Compound 4, half-maximal cytotoxic concentration: > 40000 nM
Compound 4: only a limit was reported (the forecaster's own chance of this, stated with the estimate: 85%); the middle value lies on the limit itself.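

No step can be read between compound 2 and compound 4, because both values are limits: the limit of > 40000 nM in this assay, at which 4 of the 4 values shown sit.

The compounds shown leave open where any of them would give an actual number, and so what 3-methylphenyl in place of 4-fluorophenyl does to the read-out.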